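The source may report more compounds than this note shows. Statements on the series, on what has been measured and on what is new or still open speak of the compounds shown alone.

Among the compounds with values here, compound 1 `CCOC(=O)c1cccc(-c2ccc(OCC)cc2)c1` gives 87% in an assay on COS-7 cells for inhibition of patatin-like phospholipase domain-containing protein 2 (Mus musculus), tested at 200 uM (on this read-out higher numbers stand for more inhibition at the one concentration tested (going by the name of the read-out) and lower numbers for less inhibition), the highest of the three numbers measured so far. Compound 2 `CCOC(=O)c1cccc(-c2ccc(OCC)c([N+](=O)[O-])c2)c1` gives 44%, and compound 3 `CCOC(=O)c1cccc(-c2ccc(C(C)=O)cc2)c1` gives 36%; thus a number 43 percentage points lower from compound 1 to compound 2 (beyond the scatter) and a number 51 percentage points lower from compound 1 to compound 3 (beyond the scatter). Compound 4 `CCOc1ccc(-c2cccc(C(=O)NC)c2)cc1` differs from compound 1 by methylamino in place of ethoxy on a carbonyl carbon. Neither measured step touches a carbonyl carbon; both change an aromatic carbon, so none bears directly on this change. Within the data shown here, they show only that each departure from compound 1 examined so far cost a large share of inhibition. A modest loss is therefore expected for compound 4, a number 22 percentage points lower from compound 1 to compound 4 (beyond the scatter). Compound 4 is estimated at 65%, within a range of 35% to 90%.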

Compound 4, a percentage reported as inhibition, at one concentration (the size of the read-out at that concentration, not a potency): 40%
Estimate against measurement, compound 4: 25 percentage points above, within the range that was stated.
By their numbers in this assay, from the lowest: compounds 3, 4 and 2 (each within the scatter of the next); then compound 1.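

Replacing ethoxy with methylamino on the carbonyl carbon gives, in this assay, a number 47 percentage points lower from compound 1 to compound 4 (beyond the scatter). This shows that the carbonyl end of the molecule, which neither earlier step touched, also bears on inhibition at the one concentration tested, and that ethoxycarbonyl cannot be exchanged for methylcarbamoyl without a large loss. Nothing measured here explains the loss. Only one replacement on this carbonyl carbon is shown, and whether the loss goes with the amide hydrogen or with the shorter group stays open. Dimethylamino or a carboxylic acid at this place would help to separate the two.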